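The compounds below may be only part of what the source reports. "The series", "measured", "known", "first", "only" and "open" are said of these compounds alone.

Working notes on the series. The shared core is carried by compound 1 `COC(=O)/C=C/c1cccc(N(Cc2ccc(/C=C/c3ccccc3F)cc2)C(=O)C2CCCCC2)c1`, compound 2 `COC(=O)/C=C/c1cccc(N(Cc2ccc(/C=C/c3ccc(F)cc3)cc2)C(=O)C(C)C)c1` and compound 3 `COC(=O)/C=C/c1cccc(N(Cc2ccc(/C=C/c3ccc(F)cc3)cc2)C(=O)NC(C)C)c1`. In an assay on isolated protein with Bile acid receptor (Homo sapiens) as the target (a lower number here means that less compound is needed, a higher number that more compound is needed for the effect), compound 1 gives 64 nM, compound 2 gives 120 nM and compound 3 gives 348 nM. Compound 2 thus sits second highest of the three numbers; compound 1 lies nearest, within the scatter, and compound 3 lies furthest, beyond it. Within the data shown here, the only single-point step measured so far, a 2.9-fold higher number from compound 2 to compound 3 (0.46 log units; beyond the scatter), concerns the group on the carbonyl carbon.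

Compound 4 `COC(=O)/C=C/c1cccc(N(Cc2ccc(-c3ccc(OC)cc3)cc2)C(=O)C(C)C)c1` is not yet measured. It differs from compound 2 in another place: 4-methoxyphenyl in place of 2-(4-fluorophenyl)ethenyl on an aromatic carbon. Among the measured compounds shown here, no measured step touches this part of the molecule; the step of a 2.9-fold higher number from compound 2 to compound 3 (0.46 log units; beyond the scatter) does not bear on it, and compounds 1 and 2 differ in two places at once, so they give no clean reading either. The expectation therefore rests on the structural change alone, which removes the double bond outside aromatic rings and exchanges fluorine for methoxy. A step of uncertain direction is expected in this assay, a move wider than the scatter being plausible in either sense. Compound 4 is expected at 250 nM, with a range from 70 nM to 900 nM. That estimate means an expected step of a 2.1-fold higher number from compound 2 to compound 4 (0.32 log units; beyond the scatter).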

Compound 4, half-maximal effective concentration: 97 nM
Compound 4: the middle estimate sits 2.6-fold (0.41 log units) above what was measured, and the stated range covers the measured number.
By their numbers in this assay, from the lowest: compounds 1, 4 and 2 (each within the scatter of the next); then compound 3.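

In this assay, among these compounds, 4-methoxyphenyl in place of 2-(4-fluorophenyl)ethenyl gives a 1.2-fold lower number from compound 2 to compound 4 (0.09 log units; within the scatter), the first reading at this position. It shows that this aromatic carbon accepts the exchange without a step beyond the scatter, although the double bond outside aromatic rings and the fluorine leave while a methoxy group and one hydrogen-bond acceptor enter. Among the compounds shown here, the only step beyond the scatter so far remains the change on the carbonyl carbon, a 2.9-fold higher number from compound 2 to compound 3 (0.46 log units; beyond the scatter), and no separate data bear on why the two groups at the aromatic position read alike.

Since the double bond and the ring substituent change together in this one pair, their separate contributions stay unresolved, and opposing contributions cannot be told apart from no contribution at all; a plain 4-fluorophenyl or a 2-(4-methoxyphenyl)ethenyl group on the same carbon would separate them. The compounds shown also leave open how far the position extends this tolerance, for instance to an amine in place of the methoxy group or to a longer chain on the same aromatic ring.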